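The source may hold more compounds than are shown below. What is called first, only, known or untested is meant among the compounds shown, and "the series" means these compounds.

In a functional assay on HL-60 cells (Homo sapiens) for cytotoxicity, read by luminescence and CellTiter-Glo, with a stated time of 3 days (a higher number here means a weaker inhibitor, a lower number a stronger inhibitor), the measured compounds are:
- compound 1 `N#Cc1ccc(NC(=O)c2ccc(Br)cc2O)cc1Cl`: 440 nM
- compound 2 `N#Cc1ccc(NC(=O)c2ccc(-c3cccnc3)cc2O)cc1`: 6660 nM
- compound 3 `N#Cc1ccc(NC(=O)c2ccc(F)cc2O)cc1`: 1380 nM

Compound 3 stands in the middle of these three. Its value of 1380 nM is lower than that of compound 2, at 6660 nM, and higher than that of compound 1, at 440 nM.

The next compound, compound 4 `N#Cc1ccc(NC(=O)c2ccc(Br)cc2O)cc1`, has bromo in place of fluoro on an aromatic carbon, meta to a hydroxy group and para to a large group: bromo in place of fluoro on an aromatic carbon.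

Going by the values given here, only one measured step bears on this carbon, namely a 4.8-fold lower number from compound 2 to compound 3 (0.68 log units; beyond the scatter). It shows that a change here can move the number beyond the scatter, but it involves pyridin-3-yl and says nothing direct about bromo. The closest evidence for bromo is compound 1, which carries that group and gives 440 nM. However, compound 1 also differs from compound 3 in a second place, so its value cannot be credited to bromo alone. Among the compounds with values here, no measured step isolates the exchange of fluoro for bromo.

A modest move towards a lower number is therefore expected, stopping short of the full gap to compound 1. The expected change is a 2.3-fold lower number from compound 3 to compound 4 (0.36 log units; beyond the scatter).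

For compound 4, the estimated value is 600 nM, with an expected range from 250 nM to 1500 nM.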

Compound 4, half-maximal inhibitory concentration: 1210 nM
Compound 4: the middle estimate sits 2.0-fold (0.30 log units) below what was measured; measured number inside the range.
By their numbers in this assay, from the lowest: compound 1; then compounds 4 and 3 (each within the scatter of the next); then compound 2.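

In this assay the exchange of fluoro for bromo on this aromatic carbon, meta to a hydroxy group and para to a large group, can now be read directly: it gives a 1.1-fold lower number from compound 3 to compound 4 (0.06 log units; within the scatter) and so leaves the two halogens indistinguishable at this position. Pyridin-3-yl at the same carbon stands apart from both halogens, since a 5.5-fold lower number from compound 2 to compound 4 (0.74 log units; beyond the scatter) is of about the same size as a 4.8-fold lower number from compound 2 to compound 3 (0.68 log units; beyond the scatter) in the earlier comparison. With bromo now held constant, the gap to compound 1 can be placed at the other site, where a 2.8-fold higher number from compound 1 to compound 4 (0.44 log units; beyond the scatter) comes with hydrogen in place of chloro on an aromatic carbon, so bromo does not account for the lower number of compound 1.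

On these data alone, whether an amine, a carboxylic acid or a longer chain on this carbon would fall with the halogens or with pyridin-3-yl stays open, as does whether chloro would give a similar step with fluoro rather than bromo on the core. No measurement offered here explains why these numbers fall as they do.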